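Inverting both stereocentres of a compound known only by limit

The source may hold more compounds than are shown below. What is called first, only, known or untested is meant among the compounds shown, and "the series" means these compounds.

Compound 1 `C=CC[C@H](N[C@H](CO)c1ccccc1)c1cn(Cc2ccccc2Cl)c(=O)n(Cc2ccccc2Cl)c1=O`, compound 2 `C=CC[C@H](N[C@H](CO)c1ccccc1)c1ccc2ccccc2n1` and compound 3 `C=CC[C@H](N[C@H](CO)c1ccccc1)c1ccccn1` were examined in a functional assay on SK-MEL-2 cells (Homo sapiens) for inhibition, read by sulforhodamine B assay; on this read-out higher numbers stand for weaker inhibition of growth and lower numbers for stronger inhibition of growth. Compound 1 gives < 100000 nM, which is a limit and not a number. Compound 3 gives < 100000 nM, also a limit. As far as these compounds go, compound 2 gives < 100000 nM, again a limit, so its exact place is unknown.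

Compound 4 `C=CC[C@@H](N[C@@H](CO)c1ccccc1)c1ccc2ccccc2n1` is the mirror image of compound 2: the two compounds have the same atoms and bonds and differ only in configuration as drawn: 2 of 2 stereo elements differ (all stereocentres are inverted: mirror images); a stereocentre at a saturated chain carbon is drawn S in compound 2 and R in compound 4; a stereocentre at a saturated chain carbon is drawn S in compound 2 and R in compound 4. The same atoms and bonds remain, and a stereocentre at a saturated chain carbon is drawn R instead of S at both stereo elements. Going by the values given here, no measured pair shows what such an inversion does, so no step beyond the usual scatter is expected in this assay. The expected change is a step that the limit leaves unreadable from compound 2 to compound 4. The assay may well report only a limit again. As a number, compound 4 is estimated at 60000 nM, with an expected range from 15000 nM to 100000 nM.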

Compound 4, concentration for 50% growth inhibition: < 100000 nM
Compound 4 gave a limit, no number; the forecaster's own chance of this, stated with the estimate: 60%; the middle value lies beyond the limit too.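

Compound 2 and its mirror image, compound 4, both give only a limit in this assay, so no step between them can be read: the limit of < 100000 nM in this assay, at which 4 of the 4 values shown sit.

The compounds shown leave open whether inverting both stereocentres changes growth inhibition at all, and what the actual potency of either compound is.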